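The compounds below may be only part of what the source reports. "The series", "measured", "known", "first", "only" and "open" are said of these compounds alone.

In an assay on HEK293 cells for positive allosteric modulation of metabotropic glutamate receptor 5 (Homo sapiens), read by FLIPR, with a stated time of 1 h (a higher number here means that more compound is needed for the effect, a lower number that less compound is needed), compound 2 `O=C(C1CC1)N1CCc2nc(C#Cc3ccccc3)sc2C1` gives only a limit, > 10000 nM. Compound 1 `CN1CCc2nc(C#Cc3cccc(F)c3)sc2C1` likewise returns a limit, > 10000 nM. Compound 3 `O=S(=O)(C1CCCCC1)N1CCc2nc(C#Cc3ccccc3)sc2C1` also gives a limit, > 10000 nM. Going by the values given here, all three thus sit at the limit of > 10000 nM in this assay, at which 3 of the 3 values shown sit, and no measured step between any two of them can be drawn. Compound 4 `O=C(N1CCC(F)CC1)N1CCc2nc(C#Cc3ccccc3)sc2C1` is not yet measured; compared with compound 2 it carries 4-fluoropiperidin-1-yl in place of cyclopropyl on a carbonyl carbon. Every value shown is a limit, so the data give no direction for this change. Compound 4 is therefore expected to stay close to the limit as well, at an estimated 9000 nM with a range from 2000 nM to 30000 nM. The step this estimate means, an at least 1.1-fold lower number from compound 2 to compound 4 (0.04 log units; that floor lies within the scatter), is expected to lie within the scatter.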

Compound 4, half-maximal effective concentration: 74 nM
Beside the measured number, compound 4's estimate is 120-fold (2.09 log units) above it, and the stated range ends above it.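

In this assay, going by these compounds alone, 4-fluoropiperidin-1-yl in place of cyclopropyl on a carbonyl carbon gives an at least 130-fold lower number from compound 2 to compound 4 (2.13 log units; beyond the scatter), and compound 4 holds the only value shown that is not a limit. Within the data shown here, this position can therefore carry activity, which the earlier compounds did not show. The size of the step is only a floor, since compound 2 gives a limit: the limit of > 10000 nM in this assay, at which 3 of the 4 values shown sit.

As far as these compounds go, whether the fluorine is needed stays open, because the data do not separate it from the piperidine ring. A plain piperidine, a morpholine or a dimethylamino group on the same carbonyl carbon also remains untested in what is shown here.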